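This account rests on a few compounds, and the source may have more. Where it says the series, first, only, none or still open, it means among the compounds named here.

In a functional assay on A549 cells (Homo sapiens) for inhibition, read by sulforhodamine B assay, with a stated time of 72 h (on this read-out lower numbers stand for stronger inhibition and higher numbers for weaker inhibition), the measured compounds read as follows:

- compound 1 `CCCCNC(=O)c1c(N)sc(-c2ccc(Cl)cc2)c1-c1ccc(Cl)cc1` gives 8170 nM
- compound 2 `CC(C)CNC(=O)c1c(N)sc(-c2ccc(Cl)cc2)c1-c1ccc(Cl)cc1` gives 21000 nM
- compound 3 `Nc1sc(-c2ccc(Cl)cc2)c(-c2ccc(Cl)cc2)c1C(=O)NC1CCCC1` gives 6790 nM

Compound 3 has the lowest of these three numbers. Of its two steps, a 3.1-fold lower number from compound 2 to compound 3 (0.49 log units; beyond the scatter) is a real gap, whereas a 1.2-fold lower number from compound 1 to compound 3 (0.08 log units; within the scatter) is not.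

The next compound, compound 4 `COC(=O)c1c(N)sc(-c2ccc(Cl)cc2)c1-c1ccc(Cl)cc1`, changes the same part of the molecule more deeply. The difference is methoxy in place of cyclopentylamino on a carbonyl carbon, so methoxy stands in place of cyclopentylamino on a carbonyl carbon.

The closest guides are the steps above and a 2.6-fold higher number from compound 1 to compound 2 (0.41 log units; beyond the scatter), all of which swap only the group on the amide-type nitrogen. None exceeds a modest size. Among the measured compounds shown here, no measured compound carries methoxy at this carbonyl carbon, so the direction is uncertain and the range must stay wide. A modest rise in this assay is the working expectation, and a step within the scatter is also possible.

The expected result is a 2.1-fold higher number from compound 3 to compound 4 (0.31 log units; beyond the scatter) in this estimate. For compound 4 the estimated value is 14000 nM, with an expected range from 4000 nM to 45000 nM.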

Compound 4, half-maximal inhibitory concentration: 5040 nM
The estimate for compound 4 lay 2.8-fold (0.44 log units) above the measured number, and the stated range covers the measured number.
By their numbers in this assay, from the lowest: compounds 4, 3 and 1 (each within the scatter of the next); then compound 2.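

In this assay, methoxy on the carbonyl carbon takes the place of cyclopentylamino, so the nitrogen with its hydrogen-bond donor and the five-membered ring both leave, and the result is a 1.3-fold lower number from compound 3 to compound 4 (0.13 log units; within the scatter); methoxy in place of butylamino likewise gives a 1.6-fold lower number from compound 1 to compound 4 (0.21 log units; within the scatter). Among these compounds, then, an amide-type nitrogen on this carbonyl carbon is not needed to keep the number in this range, and compound 2 alone stands apart, with a 4.2-fold lower number from compound 2 to compound 4 (0.62 log units; beyond the scatter). No measurement shown gives a reason for this pattern.

On these data alone, whether a carboxylic acid, a primary amide or a longer ester chain such as ethoxy on this carbonyl carbon would stay in the same range remains open. Also open, as far as these compounds go, is whether methoxy and cyclopentylamino would still read alike on the core with other groups in place of its two chlorophenyl groups.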